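Aryl exchange on the ring nitrogen: compound 4 pending

This account rests on a few compounds, and the source may have more. Where it says the series, first, only, none or still open, it means among the compounds named here.

Among the compounds with values here, compound 3 `COc1ccc(-n2ncnc2-c2cc(OC)c(OC)c(OC)c2)cc1` is the only member of this set with a number in a functional assay on HL-60 cells (Homo sapiens) for antiproliferative activity, read by MTT assay, with a stated time of 72 h; a lower number here means a stronger inhibitor, a higher number a weaker inhibitor: compound 3 gives 6200 nM. Compound 1 `COc1cc(-c2ncnn2-c2cccc(N)c2)cc(OC)c1OC` sits at a limit of this assay, > 10000 nM. Compound 2 `COc1cc(-c2ncnn2-c2ccccc2)cc(OC)c1OC` also returns only a limit, > 10000 nM. Both measured steps into compound 3 concern the aryl on the ring nitrogen: an at least 1.6-fold lower number from compound 1 to compound 3 (0.20 log units; that floor lies within the scatter) and an at least 1.6-fold lower number from compound 2 to compound 3 (0.20 log units; that floor lies within the scatter), with the limit of > 10000 nM in this assay, at which 2 of the 3 values shown sit, setting what can be read from them. Compound 4 `COc1cc(-c2ncnn2-c2ccc(Cl)c(Cl)c2)cc(OC)c1OC` differs from compound 3 by 3,4-dichlorophenyl in place of 4-methoxyphenyl on an aromatic nitrogen. Within the data shown here, no measured step covers this exchange, and the floors of the steps into compound 3 lie within scatter, so the expected step of a 1.2-fold lower number from compound 3 to compound 4 (0.09 log units; within the scatter) is set at no change beyond scatter. Compound 4 is therefore estimated at 5000 nM, between 1500 nM and 20000 nM.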

Compound 4, half-maximal inhibitory concentration: > 10000 nM
Compound 4 ended at the assay's limit; the forecaster's own chance of this, stated with the estimate: 40%; at least 2.0-fold (0.30 log units) between middle value and limit.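

In this assay, 3,4-dichlorophenyl on the aromatic nitrogen also gives no number, and the exchange for 4-methoxyphenyl is an at least 1.6-fold higher number from compound 3 to compound 4 (0.20 log units; that floor lies within the scatter). Of the four aryl groups now shown at this position, only 4-methoxyphenyl gives a number, though no difference beyond scatter is established. The steps from compound 1 and compound 2 to compound 4 cannot be read, and the reading of this position stays bounded: the limit of > 10000 nM in this assay, at which 3 of the 4 values shown sit.

Going by these compounds, whether 4-ethoxyphenyl or a pyridyl on this nitrogen would keep or improve on compound 3 remains open.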